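Lengthening an Alkyl Chain in a Urea Series

A few compounds are considered here, and "the series" means these few. Any claim that something is new, unique, unknown or untested is made for them only; others in the source may bear on it.

Of the compounds shown here, two from this series have been measured so far. Compound 1 `CCCCCCCCc1ccc(NC(=O)Nc2c(C(C)C)cccc2C(C)C)cc1` carries an octyl chain on one phenyl ring of a diaryl urea, and in an assay on isolated protein for inhibition of acyl-CoA:cholesterol acyltransferase (Oryctolagus cuniculus) (on this read-out higher numbers stand for weaker inhibition and lower numbers for stronger inhibition), compound 1 gives 11 nM. Compound 2 `CCCCCCCCCCc1ccc(NC(=O)Nc2c(C(C)C)cccc2C(C)C)cc1` carries a decyl chain in the same position, and in this assay compound 2 gives 13 nM. Among the two numbers known, compound 1 stands at one end, with compound 2 close by: the step of a 1.2-fold higher number from compound 1 to compound 2 (0.07 log units; within the scatter) is the only measured step available, and it is small.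

Compound 3 `CCCCCCCCCCCc1ccc(NC(=O)Nc2c(C(C)C)cccc2C(C)C)cc1` is the next member and has not yet been measured in this assay. It differs from compound 1 by propyl in place of hydrogen on a saturated chain carbon, eight bonds along the chain from an aromatic carbon. For the measured compounds named here, the one step that bears on this change, from an octyl to a decyl chain, did not move the read-out beyond the scatter, so no step beyond the scatter is expected here either. For compound 3 a value of 14 nM is estimated, in a range from 6 nM to 35 nM. That estimate corresponds to an expected step of a 1.3-fold higher number from compound 1 to compound 3 (0.10 log units; within the scatter).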

Compound 3, half-maximal inhibitory concentration: 9 nM
Beside the measured number, compound 3's estimate is 1.6-fold (0.19 log units) above it, within the range that was stated.
By their numbers in this assay, from the lowest: compounds 3, 1 and 2 (each within the scatter of the next).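

With the undecyl chain of compound 3, the series now has a third point, and the change of propyl in place of hydrogen on a saturated chain carbon, eight bonds along the chain from an aromatic carbon, gives a 1.2-fold lower number from compound 1 to compound 3 (0.09 log units; within the scatter) in this assay for this extension. The smaller change of methyl in place of hydrogen gives a 1.4-fold lower number from compound 2 to compound 3 (0.16 log units; within the scatter) on the same read-out, so each of the pairs among the octyl, decyl and undecyl chains now lies within the scatter and the numbers show no trend with chain length across these three compounds. What one step could only hint at now holds across the whole set, although nothing measured alongside these compounds says why the numbers stay so close together.

The compounds shown leave open whether a much shorter chain such as butyl, or a much longer one such as hexadecyl, would keep the read-out in the same place. They also leave open what a chain ending in an amine or a carboxylic acid would do at this position.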